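Amide aryl exchange in a weakly antiproliferative series

The source may report more compounds than this note shows. Statements on the series, on what has been measured and on what is new or still open speak of the compounds shown alone.

Within the data shown here, compound 1 `CCc1ccccc1C(=O)Nc1ccc2nc(N3CCN(CC)CC3)cc(C)c2c1` gives 23900 nM in a functional assay on SK-BR-3 cells (Homo sapiens) for antiproliferative activity, read by MTT assay, with a stated time of 72 h (on this read-out lower numbers stand for stronger inhibition and higher numbers for weaker inhibition), the only numeric value in this set. Compound 2 `Cc1cc(N(C)C)nc2ccc(NC(=O)c3ccc(Cl)c(Cl)c3)cc12` reports just a limit in this assay, > 50000 nM. Compound 2 sits at the limit of > 50000 nM in this assay, at which 1 of the 2 values shown sits. Compound 1 therefore stands as the single measured point. Compound 3 `CCN1CCN(c2cc(C)c3cc(NC(=O)c4cccnc4)ccc3n2)CC1` differs from compound 1 by pyridin-3-yl in place of 2-ethylphenyl on a carbonyl carbon. Among the measured compounds shown here, no step between measured compounds exists, so no precedent sets the size of this change. Expected is a step within the scatter, a 1.3-fold higher number from compound 1 to compound 3 (0.10 log units; within the scatter), without weakening beyond it. Compound 3 is estimated at 30000 nM, ranging from 10000 nM to 80000 nM.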

Compound 3, half-maximal inhibitory concentration: 10600 nM
For compound 3 the middle estimate is 2.8-fold (0.45 log units) above the measured one; the measured number falls inside the stated range.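

The carbonyl carbon of the amide responds to the aryl group it carries: in this assay, pyridin-3-yl in place of 2-ethylphenyl gives a 2.3-fold lower number from compound 1 to compound 3 (0.35 log units; beyond the scatter). Among these compounds, this is the first readable step, and the inhibition remains weak, with compound 3 at 10600 nM. Nothing shown accounts for the size of this step.

Open, as far as these compounds go, is whether the ring nitrogen or the loss of the ethyl chain carries the step. Plain phenyl on the same carbonyl carbon would separate the two, and pyridin-4-yl would test where the ring nitrogen sits.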